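The source may report more compounds than this note shows. Statements on the series, on what has been measured and on what is new or still open speak of the compounds shown alone.

Compound 1 `CCN1CCN(CC(=O)Nc2ccc(-c3nc(-c4ccccc4)c(-c4ccccc4)n3C)cc2)CC1` and compound 2 `CN(C)/C=C/N1CCN(CC(=O)Nc2ccc(-c3nc(-c4ccccc4)c(-c4ccccc4)n3C)cc2)CC1` share a core and differ only at an amine nitrogen in a ring. In a functional assay on HT-29 cells (Homo sapiens) for cytotoxicity, read by MTT assay, with a stated time of 24 h (a lower number here means a stronger inhibitor, a higher number a weaker inhibitor), compound 1 gives 75 ug/mL, and in this assay compound 2 gives 80 ug/mL. Compound 2 holds the higher of the two numbers, though the step of a 1.1-fold higher number from compound 1 to compound 2 (0.03 log units; within the scatter) shows that the pair sits within the scatter of the measurement. Compound 3 `Cn1c(-c2ccc(NC(=O)CN3CCN(Cc4ccccc4)CC3)cc2)nc(-c2ccccc2)c1-c1ccccc1` carries the change (benzyl in place of 2-(dimethylamino)ethenyl on an amine nitrogen in a ring). Among the measured compounds shown here, the only measured step that touches the same position, a 1.1-fold higher number from compound 1 to compound 2 (0.03 log units; within the scatter), exchanged one group on that ring nitrogen for another without moving the number beyond the scatter, so a third group at the same place is expected to behave alike. The expected step of no change at the digits printed from compound 2 to compound 3 (within the scatter) is therefore none beyond the scatter. Compound 3 is estimated at 80 ug/mL in this assay, within a range of 40 ug/mL to 160 ug/mL.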

Compound 3, half-maximal inhibitory concentration: 65.5 ug/mL
The estimate for compound 3 lay 1.2-fold (0.09 log units) above the measured number, within the range that was stated.
By their numbers in this assay, from the lowest: compounds 3, 1 and 2 (each within the scatter of the next).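

In this assay the step of a 1.2-fold lower number from compound 2 to compound 3 (0.09 log units; within the scatter) shows that this amine nitrogen in a ring can carry a group with a six-membered aromatic ring of carbon only, which neither earlier compound had, without the number moving beyond the scatter. The step of a 1.1-fold lower number from compound 1 to compound 3 (0.06 log units; within the scatter) agrees, so phenyl in place of methyl on the saturated chain carbon bound to that nitrogen likewise brings no readable change, and ethyl, 2-(dimethylamino)ethenyl and benzyl cannot be told apart here. No measurement offered here explains this result, and none is needed to state it. The compounds shown leave open whether a carboxylic acid or a hydroxyl at the end of a longer chain on this nitrogen would move the number beyond the scatter. They also leave open what a bare hydrogen there, or a chlorine on the benzyl ring, would do.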